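The source may report more compounds than this note shows. Statements on the series, on what has been measured and on what is new or still open speak of the compounds shown alone.

In a functional assay on BT-549 cells (Homo sapiens) for inhibition, read by sulforhodamine B assay, with a stated time of 48 h (on this read-out higher numbers stand for weaker inhibition of growth and lower numbers for stronger inhibition of growth), compound 1, `COc1cc(-c2nn(-c3cccc(NC(=O)Nc4cc(C(F)(F)F)cc(C(F)(F)F)c4)c3)cc2-c2ccncc2)ccc1Cl`, gives 3060 nM. Compound 2, `O=C(Nc1cccc(-n2cc(-c3ccncc3)c(-c3ccc(Cl)c(O)c3)n2)c1)Nc1cc(C(F)(F)F)cc(C(F)(F)F)c1`, differs from it by hydrogen in place of methyl on an oxygen on an aromatic ring and gives 2120 nM, so that this change made a step of a 1.4-fold lower number from compound 1 to compound 2 (0.16 log units; within the scatter). Compound 3, `COc1cc(-c2nn(-c3cccc(NC(=O)Nc4ccc(Cl)c(C(F)(F)F)c4)c3)cc2-c2ccncc2)ccc1Cl`, gives 10200 nM in this assay, the highest number among the three; the difference between its core and that of compound 1 is not broken down here. Compound 4, `O=C(Nc1cccc(-n2cc(-c3ccncc3)c(-c3ccc(Cl)c(O)c3)n2)c1)Nc1ccc(Cl)c(C(F)(F)F)c1`, is related to compound 3 by hydrogen in place of methyl on an oxygen on an aromatic ring, the same change that led from compound 1 to compound 2, at the same place. Because the earlier step was a 1.4-fold lower number from compound 1 to compound 2 (0.16 log units; within the scatter), only a small step of about a 1.4-fold lower number from compound 3 to compound 4 (0.13 log units; within the scatter) is expected from compound 3 to compound 4 in this assay. On this basis compound 4 is expected to give about 7500 nM, most likely between 3500 nM and 16000 nM.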

Compound 4, concentration for total growth inhibition: 8070 nM
For compound 4 the middle estimate is 1.1-fold (0.03 log units) below the measured one; the measured number falls inside the stated range.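

Going from methoxy to hydroxy in the 4-chloro-3-methoxyphenyl group gave a 1.3-fold lower number from compound 3 to compound 4 (0.10 log units; within the scatter) in this assay, and this step agrees with the earlier one on the other core: the same change on two cores in this assay, a 1.4-fold lower number (0.16 log units; within the scatter) from compound 1 to compound 2 and a 1.3-fold lower number (0.10 log units; within the scatter) from compound 3 to compound 4, 1.1-fold (0.06 log units) apart, within the scatter of two such steps. In these two pairs the change therefore carries over from one core to the other, and on neither core does it produce a step beyond the scatter. Among these compounds, this rests on only two cores and one assay, so it does not show that the change would behave the same way on any other core or in any other read-out.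

The compounds shown leave open whether an amine in place of the hydroxy, or a longer chain than methyl on that oxygen, would give a step beyond the scatter.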